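Swapping a bromo for a phenyl on a shared core

The source may report more compounds than this note shows. Statements on the series, on what has been measured and on what is new or still open speak of the compounds shown alone.

Of the compounds shown here, three sharing one core have been tested in a functional assay on NCI-H522 cells (Homo sapiens) for inhibition, read by sulforhodamine B assay, with a stated time of 48 h, tested at 10 uM; a lower number here means less inhibition of growth, a higher number more inhibition of growth at the concentration tested. Compound 1 `CC(=O)c1ccc(Nc2ccnc(SCC(=O)c3ccc(Br)cc3)n2)cc1` gives 29% there. Compound 2 `CCOC(=O)c1ccc(Nc2ccnc(SCC(=O)c3ccc([N+](=O)[O-])cc3)n2)cc1` gives 37%, a number higher than that of compound 1 but within the usual scatter, so the two cannot be told apart. Compound 3 `O=C(O)c1ccc(Nc2ccnc(SCC(=O)c3ccc(C(F)(F)F)cc3)n2)cc1` gives 15%, which sits below compound 1 by more than the scatter. Among the three, compound 1 therefore holds the second highest number, close to compound 2 and clearly apart from compound 3.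

Compound 4 `CC(=O)c1ccc(Nc2ccnc(SCC(=O)c3ccc(-c4ccccc4)cc3)n2)cc1` has not been measured. It differs from compound 1 in one place: phenyl in place of bromo on an aromatic carbon, that is, a phenyl in place of a bromo on an aromatic carbon, para to a large group. Going by the values given here, no measured pair in this set shows what such a change does, so the direction of the step cannot be read from the numbers that exist. With a replacement of this kind, the expectation is a step no larger than the scatter in either direction, so that compound 4 is expected to land near compound 1, the expected step from compound 1 to compound 4 being a number 3 percentage points higher from compound 1 to compound 4 (within the scatter). For compound 4 the estimate in this assay is therefore 32%, with a range from 12% to 55%.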

Compound 4, percent growth inhibition at one concentration: 22%
Estimate against measurement, compound 4: 10 percentage points above, and the stated range covers the measured number.
By their numbers in this assay, from the lowest: compounds 3, 4, 1 and 2 (each within the scatter of the next, the first and the last beyond it).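

Going by these compounds alone, the swap of bromo for phenyl is the first single change in this set that can be read directly, and in this assay it gives a number 7 percentage points lower from compound 1 to compound 4 (within the scatter). At this place, on an aromatic carbon para to a large group, the substituent can therefore grow from 1 heavy atom to 6 heavy atoms and gain a six-membered aromatic ring without the number moving beyond the usual scatter, so this pair cannot be told apart in this measurement. This single pair shows what one replacement does at one concentration, and no measurement at hand explains the outcome.

Going by these compounds, it remains open whether the number would stay within the scatter with other groups at this same place, such as an amine, a methoxy group or a longer carbon chain. Within the data shown here, compound 2 and compound 3 each differ from compound 1 in more than one place, so no single step to either can be read, and what the group on the other aromatic ring contributes by itself also stays unknown.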